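The source may hold more compounds than are shown below. What is called first, only, known or untested is meant among the compounds shown, and "the series" means these compounds.

Of the compounds shown here, three built on one shared core have been tested in a functional assay on MDA-MB-231 cells (Homo sapiens) for cytotoxicity, read by sulforhodamine B assay, with a stated time of 48 h; a higher number here means a weaker inhibitor of growth, a lower number a stronger inhibitor of growth. Compound 1 `Cc1ccc(-c2ccc(F)cc2)n1-c1ccc(-c2nc3ccccc3s2)cc1` gives 4340 nM. Compound 2 `COc1ccc(-c2ccc(C)n2-c2ccc(-c3nc4ccc(OC)cc4s3)cc2)cc1` gives 4120 nM. Compound 3 `COc1cc2nc(-c3ccc(-n4c(C)ccc4-c4ccc(C)cc4)cc3)sc2c(OC)c1OC` gives 4140 nM. All three numbers lie within the usual scatter of one another, so compound 3 stands level with the other two rather than apart from them.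

Compound 4 `COc1ccc(-c2ccc(C)n2-c2ccc(-c3nc4cc(OC)c(OC)c(OC)c4s3)cc2)cc1` has not yet been measured. It differs from compound 3 by methoxy in place of methyl on an aromatic carbon. Within the data shown here, no measured pair shows this change on its own. Compound 2 already carries a 4-methoxyphenyl group, and in this assay compound 2 gives 4120 nM, close to compound 3. The step expected from this change is a 1.0-fold lower number from compound 3 to compound 4 (0.00 log units; within the scatter), nothing beyond the scatter. Compound 4 is estimated at 4100 nM, within a range from 2000 nM to 8500 nM.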

Compound 4, concentration for 50% growth inhibition: 2240 nM
The estimate for compound 4 lay 1.8-fold (0.26 log units) above the measured number; the measured number falls inside the stated range.
By their numbers in this assay, from the lowest: compounds 4, 2, 3 and 1 (each within the scatter of the next).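

Among these compounds, this is the first direct reading of this single swap: with 4-methylphenyl changed to 4-methoxyphenyl, para to a large group, this assay shows a 1.8-fold lower number from compound 3 to compound 4 (0.27 log units; within the scatter), so the two groups cannot be told apart at this position. The entering methoxy brings one hydrogen-bond acceptor, yet the step stays inside the scatter. Nothing at hand bears on the reason for this result. Still open, as far as these compounds go, is how this position would read with a different group, such as an amine, a carboxylic acid or a longer chain.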